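Replacing Chloro with Amino on the Fused Ring

The compounds below may be only part of what the source reports. "The series", "measured", "known", "first", "only" and "open" are said of these compounds alone.

Measured so far:
compound 1, `Nc1nn(C(=O)Nc2ccc(Cc3ccccc3)cc2)c2ccccc12`: 13700 nM
compound 2, `Nc1nn(C(=O)Nc2ccc(Cc3ccccc3)cc2)c2ccc(Cl)cc12`: 1210 nM

Both compounds were tested in a functional assay on HOP-62 cells (Homo sapiens) for antiproliferative activity, read by sulforhodamine B assay, with a stated time of 48 h; a higher number here means a weaker inhibitor of growth, a lower number a stronger inhibitor of growth. Compound 2 stands at the lowest of the two numbers, and its nearest neighbour is compound 1; the step of an 11-fold lower number from compound 1 to compound 2 (1.05 log units; beyond the scatter) shows that the chloro substituent brought a large gain in growth inhibition.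

Compound 3, `Nc1ccc2c(c1)c(N)nn2C(=O)Nc1ccc(Cc2ccccc2)cc1`, differs from compound 2 in one place: amino in place of chloro on an aromatic carbon. Among the measured compounds shown here, the only step measured so far bears on it indirectly, since an 11-fold lower number from compound 1 to compound 2 (1.05 log units; beyond the scatter) shows what the chloro contributes at this position compared with hydrogen; there is no measured step showing amino at this position. With the chloro removed, the number for compound 3 is expected to move back toward that of compound 1, though how far amino restores or fails to restore the gain cannot be read from the present data, so the expected step of a 4.1-fold higher number from compound 2 to compound 3 (0.62 log units; beyond the scatter) carries wide uncertainty. For compound 3 the estimate is 5000 nM, with a range from 1000 nM to 25000 nM.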

Compound 3, concentration for 50% growth inhibition: 11200 nM
Compound 3: the middle estimate sits 2.2-fold (0.35 log units) below what was measured; the measured number falls inside the stated range.
By their numbers in this assay, from the lowest: compound 2; then compounds 3 and 1 (each within the scatter of the next).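

In this assay, the gain that chloro brought is not carried over to amino: a 9.3-fold higher number from compound 2 to compound 3 (0.97 log units; beyond the scatter). The measured step from hydrogen to amino at this place is a 1.2-fold lower number from compound 1 to compound 3 (0.09 log units; within the scatter), so these two groups cannot be told apart here, and amino keeps none of the gain that can be read from these numbers. This position therefore does not reward just any replacement of hydrogen, since of the two groups shown on this aromatic carbon, only chloro separates from hydrogen beyond the scatter, and no evidence is available to explain why chloro and amino part in this way.

From the compounds shown here alone, what remains open is where other groups fall at this place: fluoro, bromo or methyl might keep the gain seen with chloro, while hydroxyl, methoxy or a carboxylic acid might stay level with amino. Also open is whether the step from chloro to amino would keep its size on a changed core, as all three compounds shown share a single one.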